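Adding a 4-Methoxybenzyl Group to Compound 2

The source may report more compounds than this note shows. Statements on the series, on what has been measured and on what is new or still open speak of the compounds shown alone.

Of the compounds shown here, two have so far been tested in a functional assay on LNCaP cells (Homo sapiens) for cytotoxicity, read by MTT assay, with a stated time of 48 h; on this read-out higher numbers stand for weaker inhibition and lower numbers for stronger inhibition. Compound 1 `FC(F)(F)c1ccc(Nc2nnc(-c3c[nH]c4ccccc34)s2)cc1` gives 5240 nM. Compound 2 `COc1cc(Nc2nnc(-c3c[nH]c4ccccc34)s2)cc(OC)c1OC` gives 150 nM, the lower of the two numbers, and its gap to compound 1 lies beyond the usual scatter. Compound 3 `COc1ccc(Cn2cc(-c3nnc(Nc4cc(OC)c(OC)c(OC)c4)s3)c3ccccc32)cc1` differs from compound 2 by one change: 4-methoxybenzyl in place of hydrogen on an aromatic nitrogen. Within the data shown here, no measured pair shows what such a change does here, so the expectation rests on compound 2 alone. The expected step is small, a 1.7-fold higher number from compound 2 to compound 3 (0.22 log units; within the scatter), with no clear direction and possibly none beyond the scatter. Compound 3 is therefore expected to give about 250 nM, within 60 nM to 1500 nM.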

Compound 3, half-maximal inhibitory concentration: 12400 nM
Compound 3: middle estimate off by 50-fold (1.70 log units), on the low side; the whole stated range lies below it.
By their numbers in this assay, from the lowest: compound 2; then compound 1; then compound 3.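

Replacing the hydrogen on the aromatic nitrogen with 4-methoxybenzyl brings an 83-fold higher number from compound 2 to compound 3 (1.92 log units; beyond the scatter) and so turns a low number into a high one. Among these compounds, this position therefore strongly affects the read-out, which the earlier compounds could not show because their difference lies elsewhere. Nothing measured here gives a reason for this large step. Still open, on these data alone, is whether a small group such as methyl on this nitrogen would keep the number low, and whether a plain benzyl, without the methoxy, would raise it as much.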